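The source may hold more compounds than are shown below. What is called first, only, known or untested is meant among the compounds shown, and "the series" means these compounds.

Measured so far in a functional assay on MCF7 cells (Homo sapiens) for cytotoxicity, read by MTT assay, with a stated time of 24 h; a lower number here means a stronger inhibitor, a higher number a weaker inhibitor:
compound 1 `Cn1cnnc1SCC(=O)Nc1ccc(-c2nc(-c3ccccc3)c(-c3ccccc3)n2C)cc1` — 3.2 ug/mL
compound 2 `CCN1CCN(CC(=O)Nc2ccc(-c3nc(-c4ccccc4)c(-c4ccccc4)n3C)cc2)CC1` — 80 ug/mL

Compound 2 stands at the higher of the two numbers in this assay, set apart from compound 1 by a 25-fold higher number from compound 1 to compound 2 (1.40 log units; beyond the scatter). Compound 3 `Cn1c(-c2ccc(NC(=O)CN3CCN(c4ccccc4)CC3)cc2)nc(-c2ccccc2)c1-c1ccccc1` differs from compound 2 by phenyl in place of ethyl on an amine nitrogen in a ring. Among the measured compounds shown here, no measured step alters this position; the single step known, from compound 1 to compound 2, changes the whole substituent on the saturated chain carbon and shows only that this region matters, so it bears on the present change loosely. A moderate step is expected, a 2.3-fold lower number from compound 2 to compound 3 (0.36 log units; beyond the scatter), towards a lower number. Compound 3 is estimated at 35 ug/mL, within 10 ug/mL to 120 ug/mL.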

Compound 3, half-maximal inhibitory concentration: 10.7 ug/mL
Compound 3: middle estimate off by 3.3-fold (0.51 log units), on the high side, and the stated range covers the measured number.
By their numbers in this assay, from the lowest: compound 1; then compound 3; then compound 2.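

In this assay the group on the ring amine nitrogen alone moves the number, with phenyl in place of ethyl giving a 7.5-fold lower number from compound 2 to compound 3 (0.87 log units; beyond the scatter) while the rest of the molecule stays fixed. The 4-phenylpiperazin-1-yl group still leaves a 3.3-fold higher number from compound 1 to compound 3 (0.52 log units; beyond the scatter) as the gap to the (4-methyl-4H-1,2,4-triazol-3-yl)sulfanyl group. No supporting data bear on why the phenyl step occurs. Open, as far as these compounds go, is whether a benzyl group, a pyridyl ring or a chloro-substituted phenyl on this nitrogen would lower the number further.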